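The source may hold more compounds than are shown below. What is called first, only, known or untested is meant among the compounds shown, and "the series" means these compounds.

Compound 2 `CCn1c(C(=O)Nc2ccc(OC(F)(F)F)cc2)ccc1C(CC)(CC)c1ccc(OCC(=O)C(C)(C)C)c(C)c1` was tested in an assay on HL-60 cells for agonist activity at vitamin D3 receptor (Homo sapiens), read by microscopy, with a stated time of 96 h (on this read-out lower numbers stand for an effect already at smaller amounts and higher numbers for an effect only at larger amounts of compound), and gives only a limit, > 50000 nM, the same limit that the limit of > 50000 nM in this assay, at which 1 of the 2 values shown sits, marks. Compound 1 `CCOC(=O)CN(C)C(=O)c1ccc(C(CC)(CC)c2ccc(OCC(O)C(C)(C)C)c(C)c2)n1CC`, which shares the core but carries a different amide, gives 210 nM in this assay. Compound 3 `CCn1c(C(=O)Nc2ccc(OC(F)(F)F)cc2)ccc1C(CC)(CC)c1ccc(OCC(O)C(C)(C)C)c(C)c1` differs from compound 2 by 1-hydroxy-2,2-dimethylpropyl in place of (tert-butyl)carbonyl on a saturated chain carbon bound to an oxygen on an aromatic ring. For the measured compounds named here, no measured step of this kind is known here, so the expectation rests on compound 1 alone. The step of an at least 83-fold lower number from compound 2 to compound 3 (1.92 log units; beyond the scatter) is expected to be large, toward an effect at smaller amounts. Compound 3 is therefore estimated at 600 nM, within 60 nM to 15000 nM.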

Compound 3, half-maximal effective concentration: > 50000 nM
Compound 3: no number, only a limit (the forecaster's own chance of this, stated with the estimate: 20%); middle value at least 83-fold (1.92 log units) away from the limit.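

Compound 2 and compound 3 both give only limits, so the step between them cannot be read, and the change to 1-hydroxy-2,2-dimethylpropyl shows no readable effect with this amide: the limit of > 50000 nM in this assay, at which 2 of the 3 values shown sit.

With 1-hydroxy-2,2-dimethylpropyl kept, (4-(trifluoromethoxy)phenyl)amino in place of ((ethoxycarbonyl)methyl)(methyl)amino on a carbonyl carbon gives an at least 230-fold higher number from compound 1 to compound 3 (2.37 log units; beyond the scatter) in this assay. The 1-hydroxy-2,2-dimethylpropyl group alone therefore does not secure a measurable value in this series.

Still open, going by these compounds, is how (tert-butyl)carbonyl behaves alongside the ((ethoxycarbonyl)methyl)(methyl)amino amide. Also open, on these data alone, is whether a carboxylic acid in place of that ethyl ester would keep the effect.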